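A few compounds are considered here, and "the series" means these few. Any claim that something is new, unique, unknown or untested is made for them only; others in the source may bear on it.

Measured in a functional assay for inhibition of nuclear factor NF-kappa-B complex (Homo sapiens); a higher number here means a weaker inhibitor, a lower number a stronger inhibitor:
compound 1 `COc1ccc2c(c1)OC(c1cc(OC)c(OC)c(OC)c1)C(C(=O)Nc1ccccc1)=C2` gives 17500 nM
compound 2 `CCOC(=O)C1=Cc2ccc(OC)cc2OC1c1cc(OC)c(OC)c(OC)c1` gives 25000 nM

Compound 2 shows the higher of the two numbers, but its gap to compound 1 is within the scatter, so the two are not separable. Among the compounds with values here, the single measured step, a 1.4-fold higher number from compound 1 to compound 2 (0.15 log units; within the scatter), replaced the whole group on the carbonyl carbon and still moved the number only within the scatter. Compound 3 `COc1ccc2c(c1)OC(c1cc(OC)c(OC)c(OC)c1)C(C(=O)OC(C)(C)C)=C2` carries a smaller change: tert-butyl in place of ethyl on an oxygen next to a carbonyl group. Within the data shown here, no measured pair varies this alkyl, so the prior step is only a loose guide; in this assay no step beyond the scatter is expected. The estimate for compound 3 is 25000 nM (range 10000 nM to 60000 nM), and the expected step is no change at the digits printed from compound 2 to compound 3 (within the scatter).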

Compound 3, half-maximal inhibitory concentration: 14100 nM
The estimate for compound 3 lay 1.8-fold (0.25 log units) above the measured number; low and high end bracket the measured number.
By their numbers in this assay, from the lowest: compounds 3, 1 and 2 (each within the scatter of the next).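

The alkyl on an oxygen next to a carbonyl group now has its own measured pair in this assay (a 1.8-fold lower number from compound 2 to compound 3 (0.25 log units; within the scatter)), so tert-butyl and ethyl are not separable there. Tert-butoxy and anilino on the carbonyl carbon are not separable either (a 1.2-fold lower number from compound 1 to compound 3 (0.09 log units; within the scatter)), and all three groups at this carbonyl carbon lie within the scatter of one another. No measurement bearing on a cause accompanies these numbers. Open, going by these compounds, is whether a carboxylic acid or a primary amide on this carbonyl carbon, or a longer chain on the oxygen, gives a step beyond the scatter.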